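Replacing the Dimethoxyphenyl on the Sulfur with tert-Butylphenyl

The compounds below may be only part of what the source reports. "The series", "measured", "known", "first", "only" and "open" are said of these compounds alone.

Measured compounds:
compound 1, `COc1ccc(SCc2ccc(/C=C/C(=O)Nc3ccccc3N)cc2)cc1OC`, 12.9%
compound 2, `COc1ccc(SCc2ccc(C(=O)Nc3ccccc3N)cc2)cc1OC`, 33.6%

Of the compounds shown here, two have been measured so far. In a functional assay on HCT-116 cells (Homo sapiens) for inhibition, read by CCK-8 assay, with a stated time of 72 h, tested at 2 uM (on this read-out lower numbers stand for less inhibition of growth and higher numbers for more inhibition of growth at the one concentration tested), compound 1 gives 12.9%, the lowest of the two numbers. Compound 2, which lacks the two-carbon double-bond linker between the ring and the carbonyl, gives 33.6% in this assay, a number higher by an amount beyond the usual scatter. Among the compounds with values here, no step between these two has been counted, so their values are simply set side by side.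

The next compound, compound 3, `CC(C)(C)c1ccc(SCc2ccc(/C=C/C(=O)Nc3ccccc3N)cc2)cc1`, keeps the whole core of compound 1 and changes only the ring attached to the sulfur:

4-(tert-butyl)phenyl in place of 3,4-dimethoxyphenyl on a sulfur

Within the data shown here, no measured pair shows what this exchange does, so there is nothing to lean on beyond the value of compound 1. The expectation is therefore a step from compound 1 to compound 3 of a number 5.1 percentage points higher from compound 1 to compound 3 (within the scatter), that is, no change beyond the scatter, with the uncertainty leaning slightly upward. Compound 3 is estimated to give 18% in this assay, with a range from 4% to 38%.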

Compound 3, percent growth inhibition at one concentration: 6.66%
For compound 3 the middle estimate is 11.3 percentage points above the measured one; measured number inside the range.
By their numbers in this assay, from the lowest: compounds 3 and 1 (each within the scatter of the next); then compound 2.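

In this assay, within the data shown here, putting 4-(tert-butyl)phenyl in place of 3,4-dimethoxyphenyl on the sulfur gives a step of a number 6.2 percentage points lower from compound 1 to compound 3 (within the scatter), the first measured pair at this position. The entering group has the same 10 heavy atoms as the leaving group, but all of them are carbon, and it has 0 hydrogen-bond acceptors against 2, so on this core and at this one concentration the read-out does not separate an oxygen-bearing ring from an all-carbon-substituted one. Nothing measured explains this outcome, and a single pair cannot show whether other groups on the sulfur would behave alike.

From the compounds shown here alone, it remains open whether the same exchange would also stay within the scatter on the core of compound 2, which gives 33.6% and lacks the double-bond linker. The compounds shown also leave open what a ring carrying an amine or a carboxylic acid would do on the sulfur, and whether any difference would appear at another concentration.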